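Sec-Butyl on the Amide Nitrogen: Predicting Compound 4

The source may hold more compounds than are shown below. What is called first, only, known or untested is meant among the compounds shown, and "the series" means these compounds.

Measured compounds:
Compound 1, `C=CCN(Cc1ccccc1C(F)(F)F)C(=O)C1CCN(S(=O)(=O)c2ccc3[nH]ncc3c2)CC1`: in a functional assay on CHO cells for positive allosteric modulation of muscarinic acetylcholine receptor M5 (Homo sapiens), read by calcium flux (a higher number here means a larger maximal response, a lower number a smaller maximal response), compound 1 reaches 79%.
Compound 2, `CC(C)N(Cc1ccccc1C(F)(F)F)C(=O)C1CCN(S(=O)(=O)c2ccc3[nH]ncc3c2)CC1`: in this assay compound 2 reaches 54%.
Compound 3, `O=C(C1CCN(S(=O)(=O)c2ccc3[nH]ncc3c2)CC1)N(CCO)Cc1ccccc1C(F)(F)F`: in this assay compound 3 reaches 60%.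

Among these three numbers compound 3 stands second. Its gap to compound 2 is small, a number 6 percentage points higher from compound 2 to compound 3 (within the scatter), while compound 1 lies clearly above it, as a number 19 percentage points lower from compound 1 to compound 3 (beyond the scatter) shows.

Compound 4, `CCC(C)N(Cc1ccccc1C(F)(F)F)C(=O)C1CCN(S(=O)(=O)c2ccc3[nH]ncc3c2)CC1`, is the next step from compound 3. The change is sec-butyl in place of 2-hydroxyethyl on an amide-type nitrogen.

Among the compounds with values here, two measured steps bear on this. The step of a number 6 percentage points higher from compound 2 to compound 3 (within the scatter) compares a branched alkyl with the 2-hydroxyethyl group on the same amide-type nitrogen and stays within the scatter. The step of a number 25 percentage points lower from compound 1 to compound 2 (beyond the scatter) shows that a branched alkyl in place of allyl gave a modest fall. Sec-butyl is, like isopropyl, a branched alkyl without a hydrogen-bond donor or acceptor, so compound 4 is expected to land close to compound 2, which means a small step down from compound 3, a number 6 percentage points lower from compound 3 to compound 4 (within the scatter), probably within the scatter rather than beyond it.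

For compound 4 the estimated maximal response in this assay is 54%, expected to fall between 40% and 68%.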

Compound 4, largest response reached (reported as percent of maximum), in percent of the reference or control that the assay uses: 100%
For compound 4 the middle estimate is 46 percentage points below the measured one, outside the stated range (above it).
By their numbers in this assay, from the lowest: compounds 2 and 3 (each within the scatter of the next); then compound 1; then compound 4.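

On the amide-type nitrogen, the outcome turns out to depend strongly on the exact alkyl group: methyl in place of hydrogen on a saturated chain carbon, two bonds along the chain from an amide-type nitrogen, which turns isopropyl into sec-butyl, gives a number 46 percentage points higher from compound 2 to compound 4 (beyond the scatter) in this assay. Sec-butyl also exceeds both non-branched groups seen at this place, with a number 40 percentage points higher from compound 3 to compound 4 (beyond the scatter) against 2-hydroxyethyl and a number 21 percentage points higher from compound 1 to compound 4 (beyond the scatter) against allyl, so the earlier fall on going from allyl to isopropyl does not extend to branched alkyl groups as a class, and compound 4 has the highest number of the four in this assay. Nothing available here accounts for why this one added methyl produces so large a step.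

The compounds shown leave open whether the rise continues with a longer chain such as 3-pentyl or with a cyclobutyl ring on the same nitrogen. They also leave open whether the two mirror-image forms of sec-butyl give the same maximal response, and whether a methoxy group on the chain would behave like the 2-hydroxyethyl group.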